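The source may report more compounds than this note shows. Statements on the series, on what has been measured and on what is new or still open speak of the compounds shown alone.

The series shares one core: compound 1 `O=C(CCCC1CCN(C(=O)CC2CCCCC2)CC1)c1ncco1`, compound 2 `O=C(CCCC1CCN(C(=O)CCC2CCCCC2)CC1)c1ncco1` and compound 3 `CC(C)C(=O)N1CCC(CCCC(=O)c2ncco2)CC1` differ only in the group carried on the ring nitrogen. In an assay on isolated protein for inhibition of Fatty-acid amide hydrolase 1 (Homo sapiens) (on this read-out higher numbers stand for weaker inhibition and lower numbers for stronger inhibition), compound 1 gives 100 nM. In this assay compound 2 gives 3 nM. In this assay compound 3 gives 250 nM, the highest of the three numbers; the nearest is compound 1, the furthest compound 2. The steps among them are a 33-fold lower number from compound 1 to compound 2 (1.52 log units; beyond the scatter), a 2.5-fold higher number from compound 1 to compound 3 (0.40 log units; beyond the scatter) and an 83-fold higher number from compound 2 to compound 3 (1.92 log units; beyond the scatter).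

Compound 4 `O=C(CCCC1CCN(Cc2ccccc2)CC1)c1ncco1` is reached from compound 3 by benzyl in place of isopropylcarbonyl on an amine nitrogen in a ring. Within the data shown here, none of the measured steps touches this change directly: each of them swaps one carbonyl-bound chain for another while the carbonyl stays, whereas here the carbonyl itself leaves. Among the measured compounds shown here, the measured steps show only that the numbers in this assay move widely with what sits on the ring nitrogen, and that among the measured groups the larger 2-cyclohexylethyl gave the lowest number and the small isopropyl the highest. Compound 4 is therefore expected to land within the span seen so far, with the estimated step of a 2.0-fold higher number from compound 3 to compound 4 (0.30 log units; within the scatter) carrying wide uncertainty. The estimate for compound 4 in this assay is 500 nM, expected to fall between 50 nM and 5000 nM.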

Compound 4, half-maximal inhibitory concentration: 315 nM
Compound 4: the middle estimate sits 1.6-fold (0.20 log units) above what was measured, and the stated range covers the measured number.
By their numbers in this assay, from the lowest: compound 2; then compound 1; then compounds 3 and 4 (each within the scatter of the next).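

In this assay, the step is a 1.3-fold higher number from compound 3 to compound 4 (0.10 log units; within the scatter), so a ring nitrogen bearing benzyl and one bearing isopropylcarbonyl cannot be told apart on this read-out. The earlier compounds all kept a carbonyl on this amine nitrogen in a ring, and compound 4 is the first shown without one; its number lies with that of compound 3, while compound 2, at 3 nM, remains well below both on the printed values. Thus a group without that carbonyl, and with a six-membered aromatic ring of carbon only, can give a number in the same range as the small isopropylcarbonyl, though nothing at hand accounts for this result.

What the compounds shown leave open is what the carbonyl contributes on its own, as this single change removes it and replaces the chain at once. Benzoyl on the ring nitrogen would keep the carbonyl with an aromatic ring, and 2-cyclohexylethyl bound directly to that nitrogen would keep the chain of compound 2 without its carbonyl, so each would address a part of this question.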